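This account rests on a few compounds, and the source may have more. Where it says the series, first, only, none or still open, it means among the compounds named here.

Measured compounds:
- compound 1, `Cc1ccc(S(=O)(=O)Nc2cccc(-c3nc(-c4ccc(NC(=O)c5cccnc5)cc4Cl)no3)c2)cc1`: in a functional assay on MDA-MB-231 cells (Homo sapiens) for antiproliferative activity, read by MTT assay, with a stated time of 72 h (a higher number here means a weaker inhibitor, a lower number a stronger inhibitor), compound 1 gives > 10000 nM, a limit of the assay rather than a number.
- compound 2, `CC(=O)Nc1ccc(S(=O)(=O)Nc2cccc(-c3nc(-c4ccc(NC(=O)c5cccnc5)cc4Cl)no3)c2)cc1`: in this assay compound 2 gives 2500 nM.
- compound 3, `NC(=O)Nc1ccc(S(=O)(=O)Nc2cccc(-c3nc(-c4ccc(NC(=O)c5cccnc5)cc4Cl)no3)c2)cc1`: in this assay compound 3 gives 2800 nM.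

Compound 3 carries the higher of the two numbers available, but its nearest neighbour, compound 2, is separated from it only by a 1.1-fold higher number from compound 2 to compound 3 (0.05 log units; within the scatter), a gap within the scatter, so the two are not distinguished. The third value is a limit, (the limit of > 10000 nM in this assay, at which 1 of the 3 values shown sits), and gives no number to rank. The two steps away from compound 1, an at least 4.0-fold lower number from compound 1 to compound 2 (0.60 log units; beyond the scatter) and an at least 3.5-fold lower number from compound 1 to compound 3 (0.55 log units; beyond the scatter), both concern the substituent on the aromatic carbon and both are beyond the scatter.

Compound 4, `CCN(CC)C(=O)Nc1ccc(S(=O)(=O)Nc2cccc(-c3nc(-c4ccc(NC(=O)c5cccnc5)cc4Cl)no3)c2)cc1`, differs from compound 3 by diethylamino in place of amino on a carbonyl carbon. Within the data shown here, the only measured step at the same place is a 1.1-fold higher number from compound 2 to compound 3 (0.05 log units; within the scatter), which stays within the scatter; the steps at the aromatic carbon do not speak to a change on the carbonyl carbon. The expectation for compound 4 in this assay is therefore no step beyond the scatter, with the gap expected to be a 1.1-fold higher number from compound 3 to compound 4 (0.06 log units; within the scatter). Compound 4 is estimated at 3200 nM, in the range 1200 nM to 9000 nM.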

Compound 4, half-maximal inhibitory concentration: 8700 nM
For compound 4 the middle estimate is 2.7-fold (0.43 log units) below the measured one; the range from low to high includes it.
By their numbers in this assay, from the lowest: compounds 2 and 3 (each within the scatter of the next); then compound 4. At a limit, above all of these: compound 1.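

Working notes on the carbonyl carbon: in this assay amino in place of methyl gave only a 1.1-fold higher number from compound 2 to compound 3 (0.05 log units; within the scatter), which left this place looking indifferent to the group it carries, but diethylamino in place of amino gives a 3.1-fold higher number from compound 3 to compound 4 (0.49 log units; beyond the scatter) and diethylamino in place of methyl gives a 3.5-fold higher number from compound 2 to compound 4 (0.54 log units; beyond the scatter). The place therefore does respond to substitution, though the response appears only with the larger group, and the change from amino to diethylamino brings 5 heavy atoms in place of 1 and removes the 1 hydrogen-bond donor of amino, so that size and donor count move together in this single step. The remaining step, an at least 1.1-fold lower number from compound 1 to compound 4 (0.06 log units; that floor lies within the scatter), cannot be read, because it starts from a limit and its floor lies within the scatter: the limit of > 10000 nM in this assay, at which 1 of the 4 values shown sits.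

Still open, going by these compounds, is whether the number rises with chain length alone or with loss of the remaining hydrogen on that nitrogen, a question that methylamino or ethylamino on the same carbonyl carbon would address by keeping the donor. Also open, on these data alone, is how a ring amine such as pyrrolidine or morpholine would compare with the open diethylamino chain at this place.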